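Methyl for methoxy on the pendant phenyl ring

A few compounds are considered here, and "the series" means these few. Any claim that something is new, unique, unknown or untested is made for them only; others in the source may bear on it.

Three compounds share one core. Compound 1 `CCc1nc2sccn2c1/C=N/OCc1ccc(Cl)c(Cl)c1` gives 2600 nM in an assay on HepG2 cells for agonist activity at nuclear receptor subfamily 1 group I member 3 (Homo sapiens), read by a luciferase reporter, with a stated time of 23 h; on this read-out lower numbers stand for an effect already at smaller amounts and higher numbers for an effect only at larger amounts of compound. Compound 2 `Clc1ccc(CO/N=C/c2c(-c3ccc(Br)cc3)nc3sccn23)cc1Cl` gives 480 nM, and compound 3 `COc1ccc(-c2nc3sccn3c2/C=N/OCc2ccc(Cl)c(Cl)c2)cc1` gives 490 nM. Two steps reach beyond the scatter: a 5.4-fold lower number from compound 1 to compound 2 (0.73 log units; beyond the scatter) and a 5.3-fold lower number from compound 1 to compound 3 (0.72 log units; beyond the scatter). By contrast there is a 1.0-fold higher number from compound 2 to compound 3 (0.01 log units; within the scatter). Compound 3 thus stands second highest of the three numbers, within the scatter of compound 2 and well apart from compound 1.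

Compound 4 `Cc1ccc(-c2nc3sccn3c2/C=N/OCc2ccc(Cl)c(Cl)c2)cc1` differs from compound 3 by methyl in place of methoxy on an aromatic carbon. Going by the values given here, the only measured step that touches this position, bromo to methoxy, stayed within the scatter, so no change beyond the scatter is expected in this assay. Compound 4 is therefore estimated at 500 nM, between 250 nM and 1000 nM. The step this implies, a 1.0-fold higher number from compound 3 to compound 4 (0.01 log units; within the scatter), is expected to be small.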

Compound 4, half-maximal effective concentration: 490 nM
Estimate against measurement, compound 4: 1.0-fold (0.01 log units) above, and the stated range covers the measured number.
By their numbers in this assay, from the lowest: compounds 2, 3 and 4 (each within the scatter of the next); then compound 1.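

In this assay, the exchange of methoxy for methyl shows no change at the digits printed from compound 3 to compound 4 (within the scatter) and the exchange of bromo for methyl gives a 1.0-fold higher number from compound 2 to compound 4 (0.01 log units; within the scatter), so bromo, methoxy and methyl on this aromatic carbon all read alike within the scatter. The step away from ethyl also holds with a third aryl group, with a 5.3-fold lower number from compound 1 to compound 4 (0.72 log units; beyond the scatter) for 4-methylphenyl. No measurement at hand explains why these groups read alike. As far as these compounds go, whether this holds for an amine, a carboxylic acid or a longer chain at this position remains open.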